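The compounds below may be only part of what the source reports. "The series", "measured", "known", "first", "only" and "open" are said of these compounds alone.

Compound 1 `Cc1nc(C(F)(F)F)ccc1CNC(=O)C(C)c1ccc(NS(C)(=O)=O)c(F)c1` and compound 2 `CCC1CCC(c2nc(C(F)(F)F)ccc2CNC(=O)C(C)c2ccc(NS(C)(=O)=O)c(F)c2)CC1` share a common core and were both tested in an assay on CHO cells for antagonist activity at transient receptor potential cation channel subfamily V member 1 (Homo sapiens), read by FLIPR and calcium flux; on this read-out lower numbers stand for stronger inhibition and higher numbers for weaker inhibition. In this assay compound 1 gives 387 nM, and compound 2 gives 0.3 nM. Among the compounds with values here, the single measured step, a 1300-fold lower number from compound 1 to compound 2 (3.11 log units; beyond the scatter), is the only change in the set with a number attached. On the values available, compound 2 stands with the lowest number of the two, and compound 1 is its nearest neighbour at a far higher value.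

Compound 3 `CCC/C=C/c1nc(C(F)(F)F)ccc1CNC(=O)C(C)c1ccc(NS(C)(=O)=O)c(F)c1` has not yet been measured in this assay. It differs from compound 2 in one place: pent-1-en-1-yl in place of 4-ethylcyclohexyl on an aromatic carbon. Within the data shown here, the only step that bears on this change is the one from compound 1 to compound 2, which was large and favoured the 4-ethylcyclohexyl group over methyl. Pent-1-en-1-yl, a chain of 5 heavy atoms with no ring, is smaller than the group it replaces yet larger than methyl, so compound 3 is expected to fall between the two measured compounds, with a 10-fold higher number from compound 2 to compound 3 (1.00 log units; beyond the scatter) as a moderate rise. The estimate for compound 3 is 3 nM, with a range from 0.5 nM to 20 nM.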

Compound 3, inhibition constant: 0.9 nM
For compound 3 the middle estimate is 3.3-fold (0.52 log units) above the measured one, within the range that was stated.
By their numbers in this assay, from the lowest: compound 2; then compound 3; then compound 1.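

In this assay, the earlier pair showed only that 4-ethylcyclohexyl on this aromatic carbon, next to the ring nitrogen, gave a far lower number than methyl, and it could not say whether a ring was needed. Pent-1-en-1-yl, with no ring and fewer heavy atoms, still gives a 430-fold lower number from compound 1 to compound 3 (2.63 log units; beyond the scatter), so most of the gain seen with 4-ethylcyclohexyl is kept by an open chain at this position. Exchanging 4-ethylcyclohexyl for this chain gives only a 3.0-fold higher number from compound 2 to compound 3 (0.48 log units; beyond the scatter), a step beyond the scatter that leaves 4-ethylcyclohexyl with a modest edge, though nothing at hand explains the size of either step.

This exchange changes the ring, the double bond and the heavy-atom count all at once, so the compounds shown do not separate these features, and a saturated pentyl chain or a plain cyclohexyl group on the same carbon would bear on that. All three groups at this position are carbon only, which leaves open how it would respond to an amine, an ether chain or a carboxylic acid, and whether a longer chain would hold the same level.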